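The source may hold more compounds than are shown below. What is called first, only, known or untested is meant among the compounds shown, and "the series" means these compounds.

Of the compounds shown here, three sharing one core have numbers so far in a functional assay on MGC-803 cells (Homo sapiens) for inhibition, read by CCK-8 assay, with a stated time of 48 h (a higher number here means a weaker inhibitor, a lower number a stronger inhibitor), and they spread only modestly. Compound 1 (`COc1cc(N(Cc2ccc(Br)cc2)C(=O)CSC(=S)N2CCN(C(=O)OC(C)(C)C)CC2)cc(OC)c1OC`) gives 12400 nM here, compound 2 (`COc1cc(N(Cc2ccc(C)cc2)C(=O)CSC(=S)N2CCN(C(=O)OC(C)(C)C)CC2)cc(OC)c1OC`) gives 16700 nM here, and compound 3 (`COc1ccc(CN(C(=O)CSC(=S)N2CCN(C(=O)OC(C)(C)C)CC2)c2cc(OC)c(OC)c(OC)c2)cc1F`) gives 4870 nM here, the lowest of the three. Compound 4 (`COc1ccc(CN(C(=O)CSC(=S)N2CCN(C(=O)OC(C)(C)C)CC2)c2cc(OC)c(OC)c(OC)c2)cc1N=[N+]=[N-]`) carries azido in place of fluoro on an aromatic carbon. Among the measured compounds shown here, no measured step makes this exact swap. The closest one, methyl in place of bromo, gave a 1.3-fold higher number from compound 1 to compound 2 (0.13 log units; within the scatter) while changing the whole substituted phenyl gave a 2.5-fold lower number from compound 1 to compound 3 (0.41 log units; beyond the scatter) and a 3.4-fold lower number from compound 2 to compound 3 (0.54 log units; beyond the scatter) as modest steps. A small step is therefore expected in this assay with only a slight lean upward. The expected change is a 1.2-fold higher number from compound 3 to compound 4 (0.09 log units; within the scatter) as an estimate. For compound 4 the estimated value is 6000 nM with an expected range from 2200 nM to 16000 nM in this measure.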

Compound 4, half-maximal inhibitory concentration: 810 nM
Beside the measured number, compound 4's estimate is 7.4-fold (0.87 log units) above it, outside the stated range (below it).
By their numbers in this assay, from the lowest: compound 4; then compound 3; then compounds 1 and 2 (each within the scatter of the next).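

Among the compounds shown here, on this aromatic carbon, ortho to a methoxy group, replacing fluoro with azido is far from neutral in this assay and gives a 6.0-fold lower number from compound 3 to compound 4 (0.78 log units; beyond the scatter) and no step among the earlier compounds reached this size. The 3-azido-4-methoxyphenyl group also sets compound 4 well apart from the other two, with a 21-fold lower number from compound 2 to compound 4 (1.31 log units; beyond the scatter) and a 15-fold lower number from compound 1 to compound 4 (1.18 log units; beyond the scatter) as the steps. No measurement here explains the effect of the azido group. Still open, as far as these compounds go, is whether an amine or a nitrile on this carbon would give a similar result. Also open, from the compounds shown here alone, is whether azido would keep this effect if the methoxy group were replaced by hydrogen.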